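The compounds below may be only part of what the source reports. "The series", "measured", "known", "first", "only" and "open" are said of these compounds alone.

Measured in a functional assay on the whole organism with Rattus norvegicus as the target; a higher number here means that more compound is needed for the effect, a lower number that less compound is needed:
- compound 1 `CCNCCNC(=O)c1cc(Cl)c(N)cc1OC`: > 30 mg/kg (a limit)
- compound 2 `COc1cc(N)c(Cl)cc1C(=O)NCC1CCCN1Cc1ccccc1`: 1.1 mg/kg

Among the measured compounds shown here, compound 2, at 1.1 mg/kg, holds the only actual number in this assay. The entry for compound 1, > 30 mg/kg, is a limit. Compound 3 `CCN1CCCC1CNC(=O)c1cc(Cl)c(N)cc1OC` departs from compound 2 at one place, with methyl in place of phenyl on a saturated chain carbon bound to an amine nitrogen in a ring, so benzyl becomes ethyl: methyl in place of phenyl on a saturated chain carbon bound to an amine nitrogen in a ring. For the measured compounds named here, no measured pair shows this change, so the expectation is only a judgement. A rise in the required dose beyond the scatter is expected, and the expected change is a 6.4-fold higher number from compound 2 to compound 3 (0.80 log units; beyond the scatter). The estimate for compound 3 is 7 mg/kg, with an expected range of 2 mg/kg to 25 mg/kg.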

Compound 3, dose for half-maximal effect: > 30 mg/kg
Compound 3: no number, only a limit; the forecaster's own chance of this, stated with the estimate: 15%; middle value at least 4.2-fold (0.63 log units) away from the limit.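

Among the compounds shown here, the first measured pair for this change shows that, in this assay, moving from benzyl to ethyl, with methyl in place of phenyl on a saturated chain carbon bound to an amine nitrogen in a ring, gives an at least 27-fold higher number from compound 2 to compound 3 (1.43 log units; beyond the scatter). Compound 3 gives a limit, not a number, so this step has no upper end: the limit of > 30 mg/kg in this assay, at which 2 of the 3 values shown sit. The step between compound 1 and compound 3 cannot be read from two limits.

On these data alone, what stays open is whether phenyl itself is needed or whether another group would serve in place of benzyl, such as cyclohexylmethyl or a longer chain like butyl.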